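Dropping the Amino Group From the Thioether Chain

A few compounds are considered here, and "the series" means these few. Any claim that something is new, unique, unknown or untested is made for them only; others in the source may bear on it.

In an assay on HEK293 cells for antagonist activity at transient receptor potential cation channel subfamily V member 2 (Rattus norvegicus), read by fluorescence and calcium flux, with a stated time of 5 min (on this read-out higher numbers stand for weaker inhibition and lower numbers for stronger inhibition), compound 1 `CCCCCCCCCCCCCCCC(=O)NCc1ccc(O)c(OC)c1` gives only a limit, > 10000 nM, and no number. Compound 2 `CCCCCCCCCCCCCCCCOC(=O)CSC[C@H](N)C(=O)NCc1ccc(O)c(OC)c1` gives 1400 nM in this assay. Among the two values shown, that of compound 2 is the only number; the other value sits at the limit of > 10000 nM in this assay, at which 1 of the 2 values shown sits. Among the compounds with values here, compound 2 therefore stands as the one compound with a measured concentration in this assay.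

Compound 3 `CCCCCCCCCCCCCCCCOC(=O)CSCCC(=O)NCc1ccc(O)c(OC)c1` has not yet been measured in this assay. It differs from compound 2 in one place: hydrogen in place of amino on a saturated chain carbon bound to a carbonyl carbon and a saturated chain carbon. No step between two measured compounds that differ in one place is shown, so the size of this change cannot be read from any measured pair.

The account expects a moderate weakening in this assay, a step of about a 2.0-fold higher number from compound 2 to compound 3 (0.30 log units; within the scatter). Compound 3 is estimated at 2800 nM in this assay, within a range from 800 nM to 9000 nM, and a limit rather than a number is possible.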

Compound 3, half-maximal inhibitory concentration: > 10000 nM
Compound 3 ended at the assay's limit; the forecaster's own chance of this, stated with the estimate: 25%; at least 3.5-fold (0.55 log units) between middle value and limit.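

Swapping amino for hydrogen on a saturated chain carbon bound to a carbonyl carbon and a saturated chain carbon has a clear cost in this assay, giving an at least 7.1-fold higher number from compound 2 to compound 3 (0.85 log units; beyond the scatter). Compound 3 gives > 10000 nM, which is a limit of the assay and not a number, so the step has a lower bound but no measured size. This is the first single-place comparison in the set, and it ties the only number shown to the presence of the amino group, while the other values stay at the limit: the limit of > 10000 nM in this assay, at which 2 of the 3 values shown sit.

The compounds shown leave open whether the amino group itself is required or whether another group on this carbon, such as a hydroxyl, a methylamino or an acetamido group, would keep a measurable value, and whether the opposite configuration at this carbon would do the same. Within the data shown here, they also leave open what a shorter chain or a carboxylic acid in place of the long ester would do, and no step involving compound 1 can be read, as it differs from the others in more than one place.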